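The source may report more compounds than this note shows. Statements on the series, on what has been measured and on what is new or still open speak of the compounds shown alone.

Working notes on the series. In a functional assay on K562 cells (Homo sapiens) for cytotoxicity, read by MTT assay, with a stated time of 48 h (a lower number here means a stronger inhibitor, a higher number a weaker inhibitor), compound 2 `COc1ccc(CN2C(=O)C(=O)c3cc(/C=C/C(=O)N4CCCC4)ccc32)cc1` gives 460 nM, and compound 1 `CCOC(=O)/C=C/c1ccc2c(c1)C(=O)C(=O)N2Cc1ccc(OC)cc1` gives 10 nM. The change between them, (ethoxy in place of pyrrolidin-1-yl on a carbonyl carbon), produced a 46-fold lower number from compound 2 to compound 1 (1.66 log units; beyond the scatter). Compound 3 `O=C1C(=O)N(Cc2ccc(Br)cc2)c2ccc(/C=C/C(=O)N3CCCC3)cc21` gives 1710 nM, and the step of a 3.7-fold higher number from compound 2 to compound 3 (0.57 log units; beyond the scatter) leaves compound 3 with the highest number among the three measured compounds. Compound 4 `CCOC(=O)/C=C/c1ccc2c(c1)C(=O)C(=O)N2Cc1ccc(Br)cc1` is not yet measured; it stands to compound 3 as compound 1 stands to compound 2, the change being (ethoxy in place of pyrrolidin-1-yl on a carbonyl carbon), made on a core that differs from the core of compound 2 by bromo in place of methoxy on an aromatic carbon. The place of the change is the same in both pairs, so it is the same change. Within the data shown here, for compound 4 the step of a 34-fold lower number from compound 3 to compound 4 (1.53 log units; beyond the scatter) is expected, set beside the earlier one because a 46-fold lower number from compound 2 to compound 1 (1.66 log units; beyond the scatter) is the only measured instance of this change here. Compound 4 is estimated at 50 nM. Compound 4 is expected to fall between 12 nM and 250 nM.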

Compound 4, half-maximal inhibitory concentration: 30 nM
Estimate against measurement, compound 4: 1.7-fold (0.22 log units) above; low and high end bracket the measured number.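

In this assay, ethoxy in place of pyrrolidin-1-yl on the carbonyl carbon carries over to the core of compound 3, giving a 57-fold lower number from compound 3 to compound 4 (1.76 log units; beyond the scatter), and the two instances agree: the same change on two cores in this assay, a 46-fold lower number (1.66 log units; beyond the scatter) from compound 2 to compound 1 and a 57-fold lower number (1.76 log units; beyond the scatter) from compound 3 to compound 4, 1.2-fold (0.09 log units) apart, within the scatter of two such steps

Bromo in place of methoxy on the aromatic carbon also reads alike in the ethoxy pair, with a 3.0-fold higher number from compound 1 to compound 4 (0.48 log units; beyond the scatter), and the two instances again agree: the same change on two cores in this assay, a 3.7-fold higher number (0.57 log units; beyond the scatter) from compound 2 to compound 3 and a 3.0-fold higher number (0.48 log units; beyond the scatter) from compound 1 to compound 4, 1.2-fold (0.09 log units) apart, within the scatter of two such steps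

The two changes therefore behave as additive within these four compounds, but one closed set of four does not show why, nor that this holds on any other core.

The compounds shown leave open how a carboxylic acid, a piperidin-1-yl amide or a longer alkoxy chain would read on that carbonyl carbon. Also open, from the compounds shown here alone, is whether a nitrile or a chloro group in place of the bromo would fit the same pattern.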